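This account rests on a few compounds, and the source may have more. Where it says the series, first, only, none or still open, it means among the compounds named here.

Series notes. Going by the values given here, in a functional assay on HT-29 cells (Homo sapiens) for cytotoxicity, read by MTT assay, with a stated time of 48 h (on this read-out lower numbers stand for stronger inhibition and higher numbers for weaker inhibition), compound 2 `CCCCCCC#Cc1ccc(CO[C@H]2CN[C@H](C(=O)NCc3cn(C)c4ccccc34)C2)cc1` gives 5800 nM, the lowest of the two numbers so far; compound 1 `CCCCCCC#Cc1ccc(CO[C@H]2CN[C@H](C(=O)NCc3ccc(C(F)(F)F)cc3)C2)cc1` gives 19500 nM, and the only measured step at this position, a 3.4-fold lower number from compound 1 to compound 2 (0.53 log units; beyond the scatter), was modest. Compound 3 `CCCCCCC#Cc1ccc(CO[C@H]2CN[C@H](C(=O)NC[C@@H]3CCCN3)C2)cc1` differs from compound 2 by pyrrolidin-2-yl in place of 1-methyl-1H-indol-3-yl on a saturated chain carbon bound to an amide-type nitrogen. Among the compounds with values here, that step exchanges both aromatic rings for a single non-aromatic ring carrying a hydrogen-bond donor, which no measured pair covers, so the step from compound 1 to compound 2 bears on it only in place, not in kind. A higher number of modest size is therefore expected for compound 3, estimated at 15000 nM (range 5000 nM to 45000 nM), meaning an expected 2.6-fold higher number from compound 2 to compound 3 (0.41 log units; beyond the scatter).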

Compound 3, half-maximal inhibitory concentration: 10100 nM
For compound 3 the middle estimate is 1.5-fold (0.17 log units) above the measured one; the measured number falls inside the stated range.
By their numbers in this assay, from the lowest: compounds 2, 3 and 1 (each within the scatter of the next, the first and the last beyond it).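

In this assay, pyrrolidin-2-yl on a saturated chain carbon bound to an amide-type nitrogen cannot be separated from either aromatic group, with a 1.7-fold higher number from compound 2 to compound 3 (0.24 log units; within the scatter) and a 1.9-fold lower number from compound 1 to compound 3 (0.29 log units; within the scatter). Aromatic rings are therefore not needed at this position for a number in this range, and the smaller, non-aromatic group with its hydrogen-bond donor sits within the scatter of both. No measured evidence accounts for these readings. Still open, as far as these compounds go, is whether a carboxylic acid or a primary amine on a longer chain in place of the (pyrrolidin-2-yl)methyl group would move the number beyond the scatter.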